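The compounds below may be only part of what the source reports. "The series", "measured", "known", "first", "only" and "open" are said of these compounds alone.

The measured compounds and their numbers in an ADME assay on NIH3T3 cells (Mus musculus) for cytotoxicity, read by MTT assay, with a stated time of 24 h; a higher number here means a weaker inhibitor, a lower number a stronger inhibitor:

compound 1 `COc1ccc(-c2cs/c(=N/NC(=O)CSc3nnnn3-c3ccccc3)n2-c2ccccc2)cc1` gives 11.7 ug/mL
compound 2 `Cn1nnnc1SCC(=O)N/N=c1/scc(-c2ccc(Br)cc2)n1-c1ccccc1` gives 19.3 ug/mL
compound 3 `Cc1ccc(-c2cs/c(=N/NC(=O)CSc3nnnn3C)n2-c2ccccc2)cc1` gives 243 ug/mL

Compound 3 stands at the highest number of the three in this assay: its nearest neighbour is compound 2, whose number is lower by a step beyond the scatter, and compound 1 lies further down still. Compound 4 `COc1ccc(-c2cs/c(=N/NC(=O)CSc3nnnn3C)n2-c2ccccc2)cc1` is reached from compound 3 by a single change: methoxy in place of methyl on an aromatic carbon.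

Within the data shown here, only one measured step touches the same aromatic carbon, and it is large: a 13-fold higher number from compound 2 to compound 3 (1.10 log units; beyond the scatter). That step shows that what sits at this position of the ring can move the number far beyond the scatter. Among the measured compounds shown here, compound 1 carries the same methoxy group that enters in compound 4, though it differs from compound 4 in the group on the tetrazole; no step is recorded between compounds 1 and 4, so their values can only be set side by side. Compound 1 gives 11.7 ug/mL in this assay, well below compound 3, and compound 2 with bromo also sits well below compound 3. On this basis compound 4 is expected to fall in the direction of a lower number, with the step from compound 3 to compound 4 estimated as a 4.1-fold lower number from compound 3 to compound 4 (0.61 log units; beyond the scatter). Compound 4 is therefore estimated at 60 ug/mL, within a range from 15 ug/mL to 240 ug/mL.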

Compound 4, half-maximal inhibitory concentration: 45 ug/mL
The estimate for compound 4 lay 1.3-fold (0.12 log units) above the measured number; measured number inside the range.
By their numbers in this assay, from the lowest: compounds 1 and 2 (each within the scatter of the next); then compound 4; then compound 3.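

In this assay, the change from 4-methylphenyl to 4-methoxyphenyl gives a 5.4-fold lower number from compound 3 to compound 4 (0.73 log units; beyond the scatter), so a group other than bromo also brings the number well below that of the methyl compound at this aromatic carbon. Methoxy and bromo do not match, however: a 2.3-fold higher number from compound 2 to compound 4 (0.37 log units; beyond the scatter) is beyond the scatter, and the methoxy compound keeps the higher number of the two while still lying below the methyl compound. The same compound also links this series to a second site, as methyl in place of phenyl on an aromatic nitrogen, with methoxy held constant, gives a 3.8-fold higher number from compound 1 to compound 4 (0.59 log units; beyond the scatter), so this site too moves the number beyond the scatter.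

The compounds shown leave open how an amine, a carboxylic acid or a longer chain such as ethoxy would behave at this carbon, and whether the order of bromo, methoxy and methyl would hold with phenyl on the aromatic nitrogen, where only methoxy appears here. Nothing available gives a reason for any of these steps.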